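Triazole-linked pyrazole carboxamides: chloro to trifluoromethyl swap

A few compounds are considered here, and "the series" means these few. Any claim that something is new, unique, unknown or untested is made for them only; others in the source may bear on it.

Measured so far:
compound 1 `O=C(NCc1cn(Cc2ccc(C(F)(F)F)cc2)nn1)c1cn(-c2ccccc2)nc1-c1ccc(F)cc1`, 760 nM
compound 2 `O=C(NCc1cn(Cc2ccc(Cl)cc2)nn1)c1cn(-c2ccccc2)nc1-c1ccc(Cl)cc1`, 410 nM

In a functional assay on MIA PaCa-2 cells (Homo sapiens) for antiproliferative activity, read by sulforhodamine B assay, with a stated time of 48 h (a higher number here means a weaker inhibitor of growth, a lower number a stronger inhibitor of growth), compound 2 gives the lower of the two numbers, with compound 1 close enough that the two values lie within the scatter; no order between them is claimed. Compound 3 `O=C(NCc1cn(Cc2ccc(C(F)(F)F)cc2)nn1)c1cn(-c2ccccc2)nc1-c1ccc(Cl)cc1` is not yet measured. It differs from compound 2 by trifluoromethyl in place of chloro on an aromatic carbon. Compound 1 already carries a trifluoromethyl on that benzyl and sits near compound 2, so no step beyond the scatter is expected here. The expected step of a 1.4-fold higher number from compound 2 to compound 3 (0.14 log units; within the scatter) is small, and compound 3 is estimated at 560 nM, ranging from 280 nM to 1100 nM.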

Compound 3, concentration for 50% growth inhibition: 1100 nM
The estimate for compound 3 lay 2.0-fold (0.29 log units) below the measured number; low and high end bracket the measured number.
By their numbers in this assay, from the lowest: compounds 2, 1 and 3 (each within the scatter of the next, the first and the last beyond it).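

In this assay, among the compounds shown here, the change from 4-chlorobenzyl to 4-(trifluoromethyl)benzyl gives a 2.7-fold higher number from compound 2 to compound 3 (0.43 log units; beyond the scatter) and is the only step so far beyond the scatter, so the read-out does respond to the group at this benzyl position. With 4-(trifluoromethyl)benzyl held, chloro in place of fluoro on an aromatic carbon gives a 1.4-fold higher number from compound 1 to compound 3 (0.16 log units; within the scatter) and sets no order between those two compounds. Nothing available bears on why the benzyl change shifts the number.
Going by these compounds, whether a methoxy group or an amine at this benzyl position would sit nearer compound 2 or compound 3 stays open.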